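The compounds below may be only part of what the source reports. "The series", "measured", "known", "first", "only" and "open" are said of these compounds alone.

In a functional assay on MCF7 cells (Homo sapiens) for inhibition, read by radiometric assay and XTT assay (on this read-out lower numbers stand for stronger inhibition and higher numbers for weaker inhibition), two compounds sharing one core have been measured so far. Compound 1 `CCCCCC[C@@]1(C)SC(=O)C=C1OC` gives 9.4 ug/mL. Compound 2 `CCCCCC[C@@]1(C)SC(=O)C=C1OCC(=O)NCC(=O)OC` gives 40.5 ug/mL, the higher of the two numbers and therefore the weaker inhibition, and its gap to compound 1 lies beyond the usual scatter.

Compound 3 `CCCCCC[C@@]1(C)SC(=O)C=C1OCC(=O)NCC(=O)O` is still to be measured in this assay. It differs from compound 2 in one place: hydrogen in place of methyl on an oxygen next to a carbonyl group. Hydrogen stands in place of methyl on an oxygen next to a carbonyl group, so methoxycarbonyl becomes carboxy. Going by the values given here, no measured pair shows this change, so the data give no direct precedent for it. Among the compounds with values here, the only guide is that compound 2, at 40.5 ug/mL, already lies on the weaker side of compound 1, at 9.4 ug/mL. A small further rise in the number is therefore expected, though it may not clear the scatter. The estimated 1.6-fold higher number from compound 2 to compound 3 (0.21 log units; within the scatter) points toward weaker inhibition. For compound 3 the expected value is 65 ug/mL, with an estimated range from 25 ug/mL to 160 ug/mL.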

Compound 3, half-maximal inhibitory concentration: > 80 ug/mL
Compound 3: only a limit was reported; the forecaster's own chance of this, stated with the estimate: 20%; middle value at least 1.2-fold (0.09 log units) away from the limit.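

In this assay compound 3 gives only a limit of the assay, > 80 ug/mL, not a number. Going by these compounds alone, replacing methoxycarbonyl with carboxy gives an at least 1.9-fold higher number from compound 2 to compound 3 (0.29 log units; that floor lies within the scatter), the first direct reading of this change, and it shows no sign of stronger inhibition with the carboxy group, although that floor alone does not separate the two compounds. The larger comparison, with (carboxymethyl)carbamoyl in place of hydrogen on a saturated chain carbon bound to an oxygen on an unsaturated carbon, gives an at least 8.5-fold higher number from compound 1 to compound 3 (0.92 log units; beyond the scatter), which shows that the acid-ended side chain as a whole leaves inhibition clearly weaker than the small methoxy-bearing parent, with the true size of the step hidden because the reading stops at a limit: the limit of > 80 ug/mL in this assay, at which 1 of the 3 values shown sits.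

On these data alone, how far compound 3 lies past that limit remains open, and with it the full size of both steps. Also open, as far as these compounds go, is whether a primary carboxamide, an ethoxycarbonyl group or a longer chain in place of the methoxycarbonyl would keep the number closer to that of compound 1 or move it further away.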